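Trading 4-chlorophenyl for ethoxy on a carbonyl carbon

The compounds below may be only part of what the source reports. "The series", "measured", "known", "first", "only" and "open" are said of these compounds alone.

In a functional assay on HCT-116 cells (Homo sapiens) for cytotoxicity, read by MTT assay, with a stated time of 48 h (on this read-out higher numbers stand for weaker inhibition and lower numbers for stronger inhibition), compound 3 `O=C(CSCc1nc2cc([N+](=O)[O-])ccc2[nH]1)c1ccc(Cl)cc1` gives 2230 nM and compound 2 `O=[N+]([O-])c1ccc2[nH]c(CSCc3nc4cc([N+](=O)[O-])ccc4[nH]3)nc2c1` gives 2410 nM, so these two are level within the scatter. Compound 1 `O=[N+]([O-])c1ccc2[nH]c(CSCc3nc4ccccc4[nH]3)nc2c1` gives a higher number, 7910 nM.

Compound 4 `CCOC(=O)CSCc1nc2cc([N+](=O)[O-])ccc2[nH]1` has not been measured yet. It carries ethoxy in place of 4-chlorophenyl on a carbonyl carbon.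

For the measured compounds named here, the only measured step is a 3.3-fold lower number from compound 1 to compound 2 (0.52 log units; beyond the scatter), a modest change made by nitro in place of hydrogen on an aromatic carbon. Going by the values given here, compound 4 keeps a nitro group and no measured step touches the carbonyl carbon, so this step bears only indirectly. Compound 3 is still matched by compound 2 at 2410 nM, although that compound has no carbonyl at all, which suggests that a small step is more likely than a large one. The direction is poorly fixed, but a slightly higher number seems the likelier outcome.

The expected change is a 1.6-fold higher number from compound 3 to compound 4 (0.20 log units; within the scatter). For compound 4 the estimated value is 3500 nM, with an expected range from 1200 nM to 10000 nM.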

Compound 4, half-maximal inhibitory concentration: > 100000 nM
Compound 4: a limit, no number (the forecaster's own chance of this, stated with the estimate: 3%); middle value at least 28-fold (1.45 log units) away from the limit.
By their numbers in this assay, from the lowest: compounds 3 and 2 (each within the scatter of the next); then compound 1. At a limit, above all of these: compound 4.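

Trading 4-chlorophenyl for ethoxy on a carbonyl carbon gives an at least 44-fold higher number from compound 3 to compound 4 (1.65 log units; beyond the scatter) in this assay, so this position, untouched by the earlier steps, proves highly sensitive to the group it carries. This one exchange outweighs the only other step shown, a 3.3-fold lower number from compound 1 to compound 2 (0.52 log units; beyond the scatter). For compound 4 the reading is a limit of the assay and not a number: the limit of > 100000 nM in this assay, at which 1 of the 4 values shown sits.

Only these two groups appear on this carbonyl carbon, so the compounds shown cannot tell whether the ring, the chlorine or the ethoxy itself accounts for the step. A plain phenyl without chlorine would separate the ring from the chlorine, while an amine, giving an amide, or a hydroxy group, giving a carboxylic acid, would show how other small groups behave at this place.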